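The source may hold more compounds than are shown below. What is called first, only, known or untested is meant among the compounds shown, and "the series" means these compounds.

Of the compounds shown here, three have so far been tested in an ADME assay on HS27 cells (Homo sapiens) for cytotoxicity, read by MTT assay, with a stated time of 24 h; on this read-out higher numbers stand for weaker inhibition of growth and lower numbers for stronger inhibition of growth. Compound 1 (`Cc1ccc(NC(=O)c2ccccc2Sc2ccccc2C#N)cc1NC(=O)c1cnoc1C`) gives > 30000 nM here, which is a limit and not a number. Compound 2 (`Cc1ccc(NC(=O)Nc2ccccc2F)cc1NC(=O)c1cnoc1C`) gives > 30000 nM as well, again a limit. Compound 3 (`Cc1cc(NC(=O)Nc2ccccc2F)ccc1NC(=O)c1cnoc1C`), the starting point of this step, gives > 30000 nM too, so it also stands at a limit and has no exact number. The main feature of the set so far is its uniformity (the limit of > 30000 nM in this assay, at which 3 of the 3 values shown sit).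

Compound 4 (`Cc1cc(NC(=O)Nc2cc(Cl)cc(Cl)c2)ccc1NC(=O)c1cnoc1C`) differs from compound 3 in one place, with 3,5-dichlorophenyl in place of 2-fluorophenyl on an amide-type nitrogen. Going by the values given here, no measured pair of compounds shows what a swap of this kind does in this assay on its own. The expectation therefore leans on compound 3 and its limit (> 30000 nM). No step beyond the usual scatter is expected in either direction, and the estimated change (a number no higher from compound 3 to compound 4 (the limit leaves the size open)) is small. A report of only a limit is the likeliest outcome for compound 4 once more. The estimated value for compound 4 is 30000 nM with an expected range (12000 nM to 60000 nM).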

Compound 4, concentration for 50% growth inhibition: > 30000 nM
Compound 4 ended at the assay's limit; the forecaster's own chance of this, stated with the estimate: 80%; the middle value lies on the limit itself.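

Compound 4 gives > 30000 nM in this assay, which is a limit and not a number. Going by these compounds alone, compound 3 also stands at a limit, so no step between compound 3 and compound 4 can be read. The compounds shown leave open how strongly any of them inhibits growth, and all share one result: the limit of > 30000 nM in this assay, at which 4 of the 4 values shown sit.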